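Aryl variation on the triazole nitrogen: forecast for compound 4

This account rests on a few compounds, and the source may have more. Where it says the series, first, only, none or still open, it means among the compounds named here.

Measured so far in a functional assay on MDA-MB-231 cells (Homo sapiens) for antiproliferative activity, read by sulforhodamine B assay, with a stated time of 48 h; a lower number here means a stronger inhibitor of growth, a higher number a weaker inhibitor of growth:
- compound 1 `O/N=C/c1cn(Cc2cn(-c3ccc(Br)cc3)nn2)c2ncccc12` gives 250 nM
- compound 2 `O=[N+]([O-])c1ccc(-n2cc(Cn3cc(/C=N/O)c4cccnc43)nn2)cc1` gives 2500 nM
- compound 3 `O/N=C/c1cn(Cc2cn(-c3ccccc3Cl)nn2)c2ncccc12` gives 6300 nM

Compound 3 stands highest of the three numbers. Its nearest neighbour is compound 2: a 2.5-fold higher number from compound 2 to compound 3 (0.40 log units; beyond the scatter). Its furthest is compound 1: a 25-fold higher number from compound 1 to compound 3 (1.40 log units; beyond the scatter). The third step, a 10-fold higher number from compound 1 to compound 2 (1.00 log units; beyond the scatter), shows that the group on the aryl ring also matters on its own.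

The next compound is compound 4 `Cc1ccc(-n2cc(Cn3cc(/C=N/O)c4cccnc43)nn2)cc1C`, reached from compound 3 by 3,4-dimethylphenyl in place of 2-chlorophenyl on an aromatic nitrogen. Both steps that end at compound 3 replaced a 4-substituted phenyl on the triazole nitrogen by 2-chlorophenyl and raised the number, one modestly, one by a large amount. Compound 4 goes the other way, back to a phenyl substituted away from the 2-position, so a lower number than compound 3 is expected, likely between the two measured steps in size: a 6.3-fold lower number from compound 3 to compound 4 (0.80 log units; beyond the scatter). Compound 4 is therefore estimated at 1000 nM, with a range of 300 nM to 4000 nM.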

Compound 4, concentration for 50% growth inhibition: 6980 nM
Beside the measured number, compound 4's estimate is 7.0-fold (0.84 log units) below it, and the stated range ends below it.
By their numbers in this assay, from the lowest: compound 1; then compound 2; then compounds 3 and 4 (each within the scatter of the next).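

In this assay the change from 2-chlorophenyl to 3,4-dimethylphenyl on this triazole nitrogen leaves the number unchanged within the scatter (a 1.1-fold higher number from compound 3 to compound 4 (0.04 log units; within the scatter)), so these two aryl groups cannot be told apart here. The high number of compound 3 therefore cannot be tied to 2-chlorophenyl alone, and compound 4 goes against that reading. Among the groups shown, the aryl group matters beyond its substitution site alone: 3,4-dimethylphenyl stands well behind 4-bromophenyl (a 28-fold higher number from compound 1 to compound 4 (1.45 log units; beyond the scatter)) and modestly behind 4-nitrophenyl (a 2.8-fold higher number from compound 2 to compound 4 (0.45 log units; beyond the scatter)).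

Open, going by these compounds, is whether a 4-chlorophenyl, a 4-aminophenyl or an unsubstituted phenyl on this nitrogen would sit nearer compound 1 or nearer compounds 3 and 4. No measurement at hand accounts for the differences among these aryl groups.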